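This account rests on a few compounds, and the source may have more. Where it says the series, first, only, none or still open, it means among the compounds named here.

Measured compounds, all in a functional assay on A549 cells (Homo sapiens) for cytotoxicity, read by MTT assay, with a stated time of 48 h; a lower number here means a stronger inhibitor, a higher number a weaker inhibitor:

compound 1 `C=C1CC[C@@H](C(C)C)[C@]12CC=C(C=O)CC2` gives 170000 nM
compound 2 `C=C1CCC[C@]2(C)CCC(C=O)=CC[C@@]12C` gives 145000 nM
compound 3 `C#CC1=CC[C@@]2(C)C(=C)CCC[C@]2(C)CC1` gives 148000 nM

The three measured values lie close together. Compound 1 gives the highest of the three numbers, but its gaps to compound 3 and to compound 2 are both within the scatter, so no order among them can be read from these data.

Compound 2 and compound 3 share a core and differ in one place: ethynyl in place of formyl on a double-bonded ring carbon. This change produced a 1.0-fold higher number from compound 2 to compound 3 (0.01 log units; within the scatter) in this assay, a step within the scatter.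

Compound 4 `C#CC1=CC[C@]2(CC1)C(=C)CC[C@H]2C(C)C` is not yet measured. It stands to compound 1 as compound 3 stands to compound 2: ethynyl in place of formyl on a double-bonded ring carbon. The cores of compound 1 and compound 2 are built from the same atoms joined differently; the difference between the two cores is not broken down here. The surroundings of the change also differ: in compound 2 the formyl sits on a seven-membered non-aromatic ring of carbon only, with three ring bonds from two ring atoms that each bear a methyl group, while in compound 1 it sits on a six-membered non-aromatic ring of carbon only, joined to another ring at one shared atom. The change is therefore the same kind of change, not the same.

Because the step from compound 2 to compound 3 in this assay was a 1.0-fold higher number from compound 2 to compound 3 (0.01 log units; within the scatter), the step from compound 1 to compound 4 is expected to be no change at the digits printed from compound 1 to compound 4 (within the scatter), i.e. flat within the scatter. Compound 4 is thus estimated at 170000 nM, with a likely range of 85000 nM to 340000 nM.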

Compound 4, half-maximal inhibitory concentration: 103000 nM
Compound 4: middle estimate off by 1.7-fold (0.22 log units), on the high side; measured number inside the range.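

In this assay, ethynyl in place of formyl on a double-bonded ring carbon gave a 1.7-fold lower number from compound 1 to compound 4 (0.22 log units; within the scatter), so on the core of compound 1 this step also stays inside the scatter. Set side by side, the steps on the two cores do not differ, and the change carries across this pair of cores as a step that cannot be told from no step at all: the same change on two cores in this assay, a 1.0-fold higher number (0.01 log units; within the scatter) from compound 2 to compound 3 and a 1.7-fold lower number (0.22 log units; within the scatter) from compound 1 to compound 4, 1.7-fold (0.23 log units) apart, within the scatter of two such steps. This rests on two matched pairs only, so it does not show that formyl and ethynyl can be exchanged freely across the series or on other cores, and with every step here inside the scatter it gives no size or direction for the change and no reason for its outcome.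

The compounds shown leave open whether any other group on this double-bonded ring carbon, such as a carboxylic acid, an amine, a nitrile or a longer chain, would give a step beyond the scatter on either core. They also leave open whether the flat result of this exchange would hold in any other assay.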